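Nitro in place of bromo: expected cytotoxicity of compound 3

The compounds below may be only part of what the source reports. "The series", "measured", "known", "first", "only" and "open" are said of these compounds alone.

Measured in a functional assay on MCF7 cells (Homo sapiens) for cytotoxicity, read by MTT assay, with a stated time of 48 h; on this read-out lower numbers stand for stronger inhibition and higher numbers for weaker inhibition:
compound 1 `O=C(CSc1nnc(-c2ccncc2)o1)N/N=C/c1ccc(F)cc1`: 13500 nM
compound 2 `O=C(CSc1nnc(-c2ccncc2)o1)N/N=C/c1ccc(Br)cc1`: 19100 nM

Going by the values given here, compound 2 holds the higher of the two numbers, but its only neighbour is compound 1, and the step of a 1.4-fold higher number from compound 1 to compound 2 (0.15 log units; within the scatter) lies within the scatter, so the two compounds cannot be ranked against each other in this assay. Compound 3 `O=C(CSc1nnc(-c2ccncc2)o1)N/N=C/c1ccc([N+](=O)[O-])cc1` differs from compound 2 by nitro in place of bromo on an aromatic carbon. Among the compounds with values here, the single measured step that touches the same position is the halogen exchange a 1.4-fold higher number from compound 1 to compound 2 (0.15 log units; within the scatter), which was small; no measured compound carries a nitro group, so the size of this change is not covered by any measured step. On that basis the step of a 1.1-fold lower number from compound 2 to compound 3 (0.05 log units; within the scatter) is expected to be none beyond the scatter, with a wide margin for the untested group. Compound 3 is estimated at 17000 nM in this assay, expected between 6000 nM and 48000 nM.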

Compound 3, half-maximal inhibitory concentration: 31800 nM
Estimate against measurement, compound 3: 1.9-fold (0.27 log units) below; measured number inside the range.
By their numbers in this assay, from the lowest: compounds 1, 2 and 3 (each within the scatter of the next, the first and the last beyond it).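

In this assay the change from 4-bromophenyl to 4-nitrophenyl gives a 1.7-fold higher number from compound 2 to compound 3 (0.22 log units; within the scatter) and so does not separate nitro from bromo at this position. Set against fluoro, the same group gives a 2.4-fold higher number from compound 1 to compound 3 (0.37 log units; beyond the scatter) and this modest step is the first in the series to pass the scatter, which shows that the group on this aromatic carbon, para to a large group, can shift the number. Going by these compounds alone, compound 2 still cannot be separated from compound 1 or compound 3, so the three compounds do not form a firm ranking, and only the pair of compound 1 and compound 3 can be told apart.

On these data alone, whether an amine, a carboxylic acid or a longer chain at this position would fall outside the span of these three compounds remains open. Nothing available explains the difference between compound 1 and compound 3.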